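The compounds below may be only part of what the source reports. "The series", "measured", "known", "first", "only" and "open" are said of these compounds alone.

Measured in a functional assay on PC-3 cells (Homo sapiens) for inhibition; on this read-out lower numbers stand for stronger inhibition and higher numbers for weaker inhibition:
compound 1 `COc1cc2nc(N3CCN(C(=O)c4ccc(C(C)(C)C)cc4)CC3)nc(N)c2cc1OC` gives 47000 nM
compound 2 `COc1cc2nc(N3CCN(C(=O)c4ccc(C(F)(F)F)cc4)CC3)nc(N)c2cc1OC` gives only an assay limit, > 100000 nM
compound 3 `COc1cc2nc(N3CCN(S(=O)(=O)c4ccc(I)cc4)CC3)nc(N)c2cc1OC` gives 15000 nM

Compound 3 holds the lowest of the two numbers shown, compound 1 sitting well above it. The value of compound 2 is a limit rather than a number. Compound 4 `COc1cc2nc(N3CCN(S(=O)(=O)c4ccc(C(C)(C)C)cc4)CC3)nc(N)c2cc1OC` differs from compound 3 by tert-butyl in place of iodo on an aromatic carbon. Within the data shown here, no measured step exchanges iodo for tert-butyl. Among the measured compounds shown here, the only step on this position, an at least 2.1-fold higher number from compound 1 to compound 2 (0.32 log units; beyond the scatter), concerns the amide pair and shows tert-butyl giving the lower number there. Against iodo nothing is measured, so no direction beyond the scatter is expected. The step to compound 4 is therefore expected to be a 1.5-fold higher number from compound 3 to compound 4 (0.17 log units; within the scatter). The estimate for compound 4 is 22000 nM, between 7000 nM and 70000 nM.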

Compound 4, half-maximal inhibitory concentration: 4100 nM
For compound 4 the middle estimate is 5.4-fold (0.73 log units) above the measured one; measured number outside the range, below it.
By their numbers in this assay, from the lowest: compound 4; then compound 3; then compound 1. At a limit, above all of these: compound 2.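

In this assay, tert-butyl in place of iodo gives a 3.7-fold lower number from compound 3 to compound 4 (0.56 log units; beyond the scatter), so this position also responds to a change of group in the sulfonyl compounds, where earlier only an amide pair offered a step. Together with an at least 2.1-fold higher number from compound 1 to compound 2 (0.32 log units; beyond the scatter), tert-butyl carries the lower number in both pairs, though against a different group in each. The data at hand give no explanation for the new step.

Going by these compounds, how an amine or a carboxylic acid at this position would compare with tert-butyl remains open. So does the effect of a longer alkyl chain there.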